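This account rests on a few compounds, and the source may have more. Where it says the series, first, only, none or still open, it means among the compounds named here.

Compound 3 `Cc1ccc(-c2cnc(N(Cc3ccc(C(=O)NO)cc3)CC(C)C)s2)cc1` gives the highest number of the three measured in a functional assay on A549 cells (Homo sapiens) for antiproliferative activity, read by MTT assay, with a stated time of 48 h (on this read-out higher numbers stand for weaker inhibition of growth and lower numbers for stronger inhibition of growth), at 20400 nM, and its gaps to both other compounds lie beyond the scatter. Compound 1 `CCCCN(Cc1ccc(C(=O)NO)cc1)c1ncc(-c2ccc(C)cc2)s1` gives 4780 nM, and compound 2 `CCCCCCN(Cc1ccc(C(=O)NO)cc1)c1ncc(-c2ccc(C)cc2)s1` gives 3710 nM. Compound 4 `Cc1ccc(OCCCN(Cc2ccc(C(=O)NO)cc2)c2ncc(-c3ccc(C)cc3)s2)cc1` differs from compound 3 by 2-(4-methylphenoxy)ethyl in place of isopropyl on a saturated chain carbon bound to a nitrogen on an aromatic ring. Within the data shown here, two measured steps bear on this change: a 4.3-fold higher number from compound 1 to compound 3 (0.63 log units; beyond the scatter) and a 5.5-fold higher number from compound 2 to compound 3 (0.74 log units; beyond the scatter), each replacing a longer straight chain at this place by the branched isopropyl, and each raising the number. Going back in compound 4 to a longer chain, now ending in an aromatic ring, is therefore expected to lower the number in this assay by about the size of those steps, as a 5.8-fold lower number from compound 3 to compound 4 (0.77 log units; beyond the scatter). Compound 4 is accordingly estimated at 3500 nM, within 1000 nM to 12000 nM.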

Compound 4, concentration for 50% growth inhibition: 32500 nM
Compound 4: middle estimate off by 9.3-fold (0.97 log units), on the low side, and the stated range ends below it.
By their numbers in this assay, from the lowest: compounds 2 and 1 (each within the scatter of the next); then compounds 3 and 4 (each within the scatter of the next).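

At this place, a longer chain does not by itself go with a lower number in this assay: the 2-(4-methylphenoxy)ethyl group gives a 1.6-fold higher number from compound 3 to compound 4 (0.20 log units; within the scatter) and so stays level with isopropyl. The same chain end separates the aromatic-ended chain from the plain chains, with an 8.8-fold higher number from compound 2 to compound 4 (0.94 log units; beyond the scatter) and a 6.8-fold higher number from compound 1 to compound 4 (0.83 log units; beyond the scatter) on moving away from them. No measurement shown explains these steps.

Whether the oxygen or the aromatic ring accounts for the rise stays open. A 3-phenylpropyl group, or a chain ending in an amine or a carboxylic acid, would help separate these parts.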